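Swapping the Ring on the Carbonyl Carbon

The source may hold more compounds than are shown below. What is called first, only, known or untested is meant among the compounds shown, and "the series" means these compounds.

Two compounds of this series have been measured:

compound 1 `O=C(/C=C/c1ccc2c(c1)B(O)OC2)c1ccc(-c2ccccc2)cc1` gives 6400 nM in a functional assay on MDA-MB-231 cells (Homo sapiens) for cytotoxicity, read by MTT assay, with a stated time of 48 h; a higher number here means a weaker inhibitor, a lower number a stronger inhibitor
compound 2 `O=C(/C=C/c1ccc2c(c1)B(O)OC2)c1cccnc1` gives 11400 nM in this assay

Both share the same core and differ only in the ring attached to the carbonyl carbon. Of the two numbers, compound 2 has the higher one, but compound 1 sits close to it, and the gap between them lies within the usual scatter of repeated measurements, so nothing can be said about which is the better inhibitor.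

Compound 3 `Cc1cccc(C(=O)/C=C/c2ccc3c(c2)B(O)OC3)c1` has not yet been measured in this assay. It comes from compound 2 by one change: 3-methylphenyl in place of pyridin-3-yl on a carbonyl carbon. The two measured compounds show that replacing the ring on the carbonyl carbon by a different aromatic ring moved the number by less than the scatter. On that basis a step from compound 2 to compound 3 of about a 1.4-fold lower number from compound 2 to compound 3 (0.15 log units; within the scatter) is expected, that is, no change beyond the scatter. For compound 3 a value of 8000 nM is estimated, within a range from 3500 nM to 18000 nM.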

Compound 3, half-maximal inhibitory concentration: 4500 nM
Estimate against measurement, compound 3: 1.8-fold (0.25 log units) above; measured number inside the range.
By their numbers in this assay, from the lowest: compounds 3, 1 and 2 (each within the scatter of the next, the first and the last beyond it).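

In this assay the ring on the carbonyl carbon now shows an effect that the first two compounds could not show: a 2.5-fold lower number from compound 2 to compound 3 (0.40 log units; beyond the scatter) is a modest step, but it lies beyond the scatter, so this position does respond to a change of aromatic ring. The change replaces pyridin-3-yl, a ring with one hetero atom and a hydrogen-bond acceptor, with 3-methylphenyl, a ring of carbon only with no hydrogen-bond acceptor, so the ring nitrogen goes and a methyl group arrives in the same step, and this single step cannot tell the two apart. Nothing measured here bears on the reason for the step.

As far as these compounds go, what stays open is whether the loss of the ring nitrogen or the gain of the methyl group accounts for the step, a question that an unsubstituted phenyl ring on the carbonyl carbon would help to settle. Also open, from the compounds shown here alone, is how a ring carrying an amine or a carboxylic acid would fare at this position in this assay and whether the trend would hold there.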